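Removing one methyl from a compound at the assay limit

This account rests on a few compounds, and the source may have more. Where it says the series, first, only, none or still open, it means among the compounds named here.

Compound 1 `CN1CCN(/N=N/c2cc(F)ccc2F)CC1`: > 100000 nM
Compound 2 `CN(Cc1ccccc1)/N=N/c1ccccc1`: > 100000 nM

In an ADME assay on MDBK cells (Bos taurus) for cytotoxicity, read by MTT assay, with a stated time of 96 h (a lower number here means that less compound is tolerated, a higher number that more compound is tolerated), compound 2 gives > 100000 nM, which is a limit of the assay and not a number. It sits at the limit of > 100000 nM in this assay, at which 2 of the 2 values shown sit. Compound 3 `c1ccc(CN/N=N/c2ccccc2)cc1` differs from it by hydrogen in place of methyl on an amine nitrogen. Among the measured compounds shown here, no measured pair shows what this change does. The expected size is an at least 1.1-fold lower number from compound 2 to compound 3 (0.04 log units; that floor lies within the scatter), which is no step beyond the scatter, and any drift would be expected toward less compound tolerated. For compound 3 the estimate is 90000 nM, with an expected range from 30000 nM to 100000 nM.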

Compound 3, half-maximal cytotoxic concentration: > 100000 nM
Compound 3 gave a limit, no number; the forecaster's own chance of this, stated with the estimate: 60%; at least 1.1-fold (0.04 log units) between middle value and limit.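

No step can be read from compound 2 to compound 3, because both results are limits of the assay and not numbers: the limit of > 100000 nM in this assay, at which 3 of the 3 values shown sit.

On these data alone, whether hydrogen in place of methyl on an amine nitrogen changes how much compound is tolerated remains open.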